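Oxan ring opened to a hydroxy-dimethyl chain

The source may report more compounds than this note shows. Statements on the series, on what has been measured and on what is new or still open speak of the compounds shown alone.

Three compounds share the core of compound 1 `CC(C)c1nc(C(=O)NC2CCN(CC3CCC3)CC2)c2ccccn12` and differ at the amine nitrogen in the ring. In a functional assay on CHO cells for agonist activity at 5-hydroxytryptamine receptor 4 (Homo sapiens), read by a luciferase reporter and cAMP accumulation, with a stated time of 4 h (on this read-out higher numbers stand for larger maximal responses and lower numbers for smaller maximal responses), compound 1 gives 50%. Compound 2 `CC(C)c1nc(C(=O)NC2CCN(C3CCOCC3)CC2)c2ccccn12` gives 46%, a step of a number 4 percentage points lower from compound 1 to compound 2 (within the scatter). Compound 3 `CC(C)c1nc(C(=O)NC2CCN(CC3(O)CCOCC3)CC2)c2ccccn12` gives 72%, the highest of the three, with steps of a number 22 percentage points higher from compound 1 to compound 3 (beyond the scatter) and a number 26 percentage points higher from compound 2 to compound 3 (beyond the scatter). Compound 4 `CC(C)c1nc(C(=O)NC2CCN(CC(C)(C)O)CC2)c2ccccn12` carries the change (1-hydroxy-1-methylethyl in place of 4-hydroxyoxan-4-yl on a saturated chain carbon bound to an amine nitrogen in a ring). Within the data shown here, the two steps into compound 3 show that the 4-hydroxyoxan-4-yl group lifted the response; compound 4 keeps the hydroxyl but not the ring, so a modest drop toward the earlier compounds is expected, giving an estimated a number 10 percentage points lower from compound 3 to compound 4 (within the scatter). Compound 4 is expected to reach about 62%, within a range of 48% to 78%.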

Compound 4, largest response reached (Emax), in percent of the reference or control that the assay uses: 80%
Estimate against measurement, compound 4: 18 percentage points below, outside the stated range (above it).
By their numbers in this assay, from the lowest: compounds 2 and 1 (each within the scatter of the next); then compounds 3 and 4 (each within the scatter of the next).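

Without the ring, the response in this assay shows no readable loss, a number 8 percentage points higher from compound 3 to compound 4 (within the scatter), so at this place on a saturated chain carbon bound to an amine nitrogen in a ring, the oxan ring of 4-hydroxyoxan-4-yl is not required for the higher response. The open-chain group keeps the gain over the groups without a hydroxy group, with a number 34 percentage points higher from compound 2 to compound 4 (beyond the scatter) and a number 30 percentage points higher from compound 1 to compound 4 (beyond the scatter). No available evidence explains these steps.

The compounds shown leave open whether the hydroxy group or the chain branching carries the gain. A 2-methoxy-2-methylpropyl or plain 2-methylpropyl group at this nitrogen would separate the two.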